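A few compounds are considered here, and "the series" means these few. Any claim that something is new, unique, unknown or untested is made for them only; others in the source may bear on it.

Measured compounds:
Compound 1 `O=CN1CCN(c2ccc(Cl)cc2Cl)C1=S` is reported in a functional assay on MT4 cells (Homo sapiens) for antiproliferative activity, read by MTT assay (a higher number here means a weaker inhibitor, a lower number a stronger inhibitor), only as a limit, > 100000 nM.
Compound 2 `O=C(c1ccc(Cl)c(Cl)c1)N1CCCN(C(=O)c2ccc(Cl)c(Cl)c2)C1=S` gives 72000 nM in this assay.
Compound 3 `O=CN1CCN(c2ccc(Cl)cc2)C1=S` gives 27000 nM in this assay.

Compound 3 holds the lowest of the two numbers in this assay; the nearest, compound 2, stands higher by a gap beyond the scatter. The third entry, compound 1, is a limit and not a number; one of the three values sits at the limit of > 100000 nM in this assay, at which 1 of the 3 values shown sits.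

Compound 4 `O=CN1CCN(c2ccc(Cl)c(Cl)c2)C1=S` differs from compound 3 in one place: chloro in place of hydrogen on an aromatic carbon. For the measured compounds named here, the only measured step concerns a chloro group on the same ring of the same core: an at least 3.7-fold lower number from compound 1 to compound 3 (0.56 log units; beyond the scatter). There, removing a chloro lowered the number; here a chloro is added, though at a different place on the ring, so the measured step points, if anything, toward a higher number for compound 4. Compound 4 shares its ring substitution with compound 2, which sits on a different core; compound 2 gives 72000 nM, which offers no direct comparison. A modest rise in this assay is expected, with a real chance that compound 4 is reported only as a limit.

Compound 4 is estimated at 45000 nM in this assay, within 12000 nM to 150000 nM; this expectation corresponds to a 1.7-fold higher number from compound 3 to compound 4 (0.22 log units; within the scatter).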

Compound 4, half-maximal inhibitory concentration: 41000 nM
The estimate for compound 4 lay 1.1-fold (0.04 log units) above the measured number; low and high end bracket the measured number.
By their numbers in this assay, from the lowest: compounds 3, 4 and 2 (each within the scatter of the next, the first and the last beyond it). At a limit, above all of these: compound 1.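

Chloro in place of hydrogen on the aromatic carbon ortho to a chloro group and meta to a group of 8 heavy atoms gives a 1.5-fold higher number from compound 3 to compound 4 (0.18 log units; within the scatter) in this assay, so compounds 3 and 4 cannot be told apart in this assay. For the compounds shown here, this is the first measured step at this position, and it differs in reading from the only earlier step on this ring, an at least 3.7-fold lower number from compound 1 to compound 3 (0.56 log units; beyond the scatter), which involves a chloro at another place and is printed as beyond the scatter. The series therefore shows that a chloro step on this ring need not separate two compounds, although compound 1 remains a limit and not a number: the limit of > 100000 nM in this assay, at which 1 of the 4 values shown sits.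

The compounds shown leave open whether a group other than chloro at this carbon, such as methoxy, an amine or a carboxylic acid, would give a step beyond the scatter. They also leave open whether a step at this position would read the same on the core of compound 2, which carries a longer chain and two benzoyl-type carbonyl groups.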